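Methyl on an aromatic nitrogen: compound 1 to compound 3

The compounds below may be only part of what the source reports. "The series", "measured", "known", "first", "only" and "open" are said of these compounds alone.

compound 1 `Cc1cc2[nH]nc(N)c2c(=O)[nH]1`: 8%
compound 2 `CC(C)(C)c1cc2[nH]nc(N)c2c(=O)[nH]1`: 4%

Both numbers come from an assay on isolated protein for inhibition of RAC-beta serine/threonine-protein kinase (Homo sapiens), read by mobility shift assay, tested at 30 uM; on this read-out lower numbers stand for less inhibition and higher numbers for more inhibition at the one concentration tested (going by the name of the read-out). Of the two shown, compound 1 holds the higher, yet a number 4 percentage points lower from compound 1 to compound 2 (within the scatter) falls within the scatter, so the two compounds are not told apart. Compound 3 `Cc1cc2c(c(N)nn2C)c(=O)[nH]1` differs from compound 1 by methyl in place of hydrogen on an aromatic nitrogen. Within the data shown here, the only measured step, a number 4 percentage points lower from compound 1 to compound 2 (within the scatter), concerns tert-butyl in place of methyl on an aromatic carbon and does not bear directly on a change at an aromatic nitrogen. Because compound 1 gives 8% and compound 2 gives 4%, both low, the step of a number 1 percentage points lower from compound 1 to compound 3 (within the scatter) is expected to stay within the scatter. Compound 3 is estimated at 7%, in the range -5% to 20%.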

Compound 3, a percentage reported as inhibition, at one concentration (the size of the read-out at that concentration, not a potency): 4%
Compound 3: the middle estimate sits 3 percentage points above what was measured; low and high end bracket the measured number.
By their numbers in this assay, from the lowest: compounds 2, 3 and 1 (each within the scatter of the next).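

In this assay, methyl in place of hydrogen on the aromatic nitrogen gives a number 4 percentage points lower from compound 1 to compound 3 (within the scatter) and so does not set compound 3 apart from compound 1. Among these compounds, this is the first reading at this nitrogen, and here methyl and hydrogen cannot be told apart. Nothing available explains this result.

On these data alone, whether a longer chain, a benzyl group or a chain ending in a carboxylic acid on this nitrogen would move the number beyond the scatter remains open. Also open, as far as these compounds go, is whether any change at this nitrogen would raise inhibition.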